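The compounds below may be only part of what the source reports. "The series", "measured", "known", "first", "only" and "open" are said of these compounds alone.

Measured compounds:
Compound 1, `Cc1ccc(-c2ccc(F)cc2)n1-c1ccc(-c2nc3ccccc3s2)cc1`, 4340 nM
Compound 2, `COc1ccc(-c2ccc(C)n2-c2ccc(-c3nc4ccccc4s3)cc2)cc1`, 3990 nM
Compound 3, `Cc1ccc(-c2ccc(C)n2-c2ccc(-c3nc4ccc(F)cc4s3)cc2)cc1`, 3140 nM

All three were tested in a functional assay on MDA-MB-231 cells (Homo sapiens) for cytotoxicity, read by sulforhodamine B assay, with a stated time of 48 h; on this read-out lower numbers stand for stronger inhibition of growth and higher numbers for weaker inhibition of growth. Compound 1 and compound 2 differ in one place: methoxy in place of fluoro on an aromatic carbon. That change brought a 1.1-fold lower number from compound 1 to compound 2 (0.04 log units; within the scatter). Compound 3 carries a different core; how it differs from compound 1 is not broken down here. Among the three, compound 3 gives the lowest number, but its gaps to compound 2 and to compound 1 are both within the scatter, so no order among them can be read from these values.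

Compound 4, `COc1ccc2nc(-c3ccc(-n4c(C)ccc4-c4ccc(C)cc4)cc3)sc2c1`, has not yet been measured in this assay. It differs from compound 3 by methoxy in place of fluoro on an aromatic carbon. For the measured compounds named here, this is the same kind of change as the one from compound 1 to compound 2, though not the same: in compound 2 the methoxy sits on a six-membered aromatic ring of carbon only, para to a large group, whereas in compound 4 it sits on a six-membered aromatic ring of carbon only that is part of a fused or bridged system of two rings, meta to a fused ring and para to a fused ring.

Because the earlier step read a 1.1-fold lower number from compound 1 to compound 2 (0.04 log units; within the scatter), compound 4 is expected to show a similarly small step, a 1.1-fold higher number from compound 3 to compound 4 (0.02 log units; within the scatter), from compound 3. Compound 4 is therefore estimated at 3300 nM, most likely between 1500 nM and 7500 nM.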

Compound 4, concentration for 50% growth inhibition: 4010 nM
Beside the measured number, compound 4's estimate is 1.2-fold (0.08 log units) below it, and the stated range covers the measured number.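

In this assay, methoxy in place of fluoro on an aromatic carbon that is part of a fused or bridged system of two rings gives a 1.3-fold higher number from compound 3 to compound 4 (0.11 log units; within the scatter), so on the core of compound 3 this exchange leaves no change that can be told from the scatter. Set beside the earlier step on the aryl ring of compound 1, the exchange reads alike on both cores, with no sign that the core alters its outcome: the same change on two cores in this assay, a 1.1-fold lower number (0.04 log units; within the scatter) from compound 1 to compound 2 and a 1.3-fold higher number (0.11 log units; within the scatter) from compound 3 to compound 4, 1.4-fold (0.14 log units) apart, within the scatter of two such steps. For the compounds shown here, this shows only that the exchange stayed within the scatter in two pairs, at two different places, in one cell line; it does not show that the exchange would stay as small on a further core or at another place, and with steps this small it gives no measure of how far the two cores could differ.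

The compounds shown leave open whether any group other than fluoro or methoxy at these places would move the number beyond the scatter, for example an amine, a carboxylic acid or a longer alkoxy chain. They also leave open how a plain hydrogen at either place would compare with these two groups.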